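A few compounds are considered here, and "the series" means these few. Any claim that something is new, unique, unknown or untested is made for them only; others in the source may bear on it.

Compound 3, the aminated core carrying a selenol, is `Nc1nc([SeH])nc2ncccc12`. In an ADME assay on 184B5 cells (Homo sapiens) for cytotoxicity, read by MTT assay, with a stated time of 72 h (on this read-out lower numbers stand for stronger inhibition of growth and higher numbers for weaker inhibition of growth), compound 3 gives 5200 nM, which is the second highest of the three numbers recorded. Its nearest neighbour is compound 2, `COc1ccc(CNc2nc([SeH])nc3ccccc23)cc1`, which in this assay gives the higher figure of 71300 nM, a gap beyond the scatter. Furthest from it stands compound 1, `CSc1ccc(CNc2nc(SC)nc3ncccc23)cc1`, which in this assay gives 190 nM, a gap that also lies beyond the scatter. Compound 4, `C[Se]c1nc(N)c2cccnc2n1`, differs from compound 3 by methyl in place of hydrogen on a selenium. Among the measured compounds shown here, no measured pair shows this change, but compound 1, which carries methyl on sulfur, gives 190 nM, so a modest lowering of the number is expected, a 2.1-fold lower number from compound 3 to compound 4 (0.32 log units; beyond the scatter). For compound 4 the estimated value in this assay is 2500 nM, within a range from 600 nM to 10000 nM.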

Compound 4, concentration for 50% growth inhibition: 45500 nM
Estimate against measurement, compound 4: 18-fold (1.26 log units) below, and the stated range ends below it.
By their numbers in this assay, from the lowest: compound 1; then compound 3; then compounds 4 and 2 (each within the scatter of the next).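

Methyl in place of hydrogen on a selenium weakens growth inhibition in this assay, with an 8.8-fold higher number from compound 3 to compound 4 (0.94 log units; beyond the scatter), the first direct reading of this change. For this pair, the form with hydrogen on the selenium goes with the stronger inhibition of growth. Nothing at hand accounts for this step. From the compounds shown here alone, it remains open whether an ethyl group or a longer chain on the selenium would raise the number further or bring it back down. Going by these compounds, whether a benzyl group there would behave like methyl also remains open.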